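The source may hold more compounds than are shown below. What is called first, only, known or untested is meant among the compounds shown, and "the series" means these compounds.

Compound 1, `COc1ccc(C2N=C(SCc3cccc(Cl)c3)NC(C)=C2C(=O)Nc2ccc(F)cc2)cc1OC`, gives 8.2% in a functional assay on the whole organism (artery, strain albino) with Rattus norvegicus as the target, with a stated time of 60 min, at a dose of 10 mg/kg by the oral route; a lower number here means less inhibition, a higher number more inhibition at the dose given (going by the name of the read-out).
Compound 2, `COc1ccc(C2N=C(SCc3ccc(Cl)cc3)NC(C)=C2C(=O)Nc2ccc(F)cc2)cc1OC`, gives 10.3%.
Compound 3, `CC1=C(C(=O)Nc2ccc(F)cc2)C(c2ccc([N+](=O)[O-])cc2)N=C(SCc2cccc(Cl)c2)N1`, gives 7.2%.

Compound 1 and compound 2 share a core and differ in one place: 4-chlorophenyl in place of 3-chlorophenyl on a saturated chain carbon bound to a sulfur. This change gave a number 2.1 percentage points higher from compound 1 to compound 2 (within the scatter). Compound 3 carries a different core, which differs from that of compound 1 as follows: 4-nitrophenyl in place of 3,4-dimethoxyphenyl on a saturated ring carbon. That difference gave a number 1 percentage points lower from compound 1 to compound 3 (within the scatter). Compound 4, `CC1=C(C(=O)Nc2ccc(F)cc2)C(c2ccc([N+](=O)[O-])cc2)N=C(SCc2ccc(Cl)cc2)N1`, has not yet been measured. It differs from compound 3 by 4-chlorophenyl in place of 3-chlorophenyl on a saturated chain carbon bound to a sulfur, the same change as that between compound 1 and compound 2, at the same place. The step from compound 3 to compound 4 is expected to be a number 1.8 percentage points higher from compound 3 to compound 4 (within the scatter). This expectation rests on the step of a number 2.1 percentage points higher from compound 1 to compound 2 (within the scatter) lying within the scatter and on the value of compound 3, 7.2%. Compound 4 is therefore expected to give about 9% in this assay, most likely between 2% and 17%.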

Compound 4, a percentage reported as inhibition, in the whole organism at one dose (the size of the read-out at that dose, not a potency): 11.8%
For compound 4 the middle estimate is 2.8 percentage points below the measured one; low and high end bracket the measured number.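

Both changes carried from one core to the other without the two steps parting, first the exchange of 3-chlorophenyl for 4-chlorophenyl: the same change on two cores in this assay, a number 2.1 percentage points higher (within the scatter) from compound 1 to compound 2 and a number 4.6 percentage points higher (within the scatter) from compound 3 to compound 4, 2.5 percentage points apart, within the scatter of two such steps. The exchange of 3,4-dimethoxyphenyl for 4-nitrophenyl behaved likewise: the same change on two cores in this assay, a number 1 percentage points lower (within the scatter) from compound 1 to compound 3 and a number 1.5 percentage points higher (within the scatter) from compound 2 to compound 4, 2.5 percentage points apart, within the scatter of two such steps. In this assay, for the compounds shown here, the new steps, a number 4.6 percentage points higher from compound 3 to compound 4 (within the scatter) and a number 1.5 percentage points higher from compound 2 to compound 4 (within the scatter), are themselves small, so the agreement shows only that neither change moved the number measurably on either core, not that either has a real effect that transfers.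

The compounds shown leave open what larger changes would do. An unsubstituted phenyl or a longer alkyl chain on the saturated chain carbon bound to a sulfur, or an amine in place of the nitro group, might still move the number beyond the scatter.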